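The source may report more compounds than this note shows. Statements on the series, on what has been measured and on what is new or still open speak of the compounds shown alone.

Working notes on the series. Compound 1 `CO/N=C1\C(=O)N(CCCN2CCN(c3cc4c(cc3F)c(=O)c(C(=O)O)cn4C3CC3)CC2)c2ccc(C)cc21` and compound 2 `O=C1C(=O)N(CCCN2CCN(c3cc4c(cc3F)c(=O)c(C(=O)O)cn4C3CC3)CC2)c2ccccc21` share a core and differ at the ring-fused dione end. In an ADME assay on Vero cells (Chlorocebus sabaeus) for cytotoxicity, read by MTT assay, with a stated time of 72 h (on this read-out higher numbers stand for lower toxicity in this test and lower numbers for higher toxicity in this test), compound 1 gives 256 ug/mL; in this assay compound 2 gives 128 ug/mL. The gap between these two values lies within the usual scatter of this assay, so compound 2 cannot be separated from compound 1 on this read-out, and nothing more is known about the direction of that pair.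

The next compound, compound 3 `Cc1ccc2c(c1)C(=O)C(=O)N2CCCN1CCN(c2cc3c(cc2F)c(=O)c(C(=O)O)cn3C2CC2)CC1`, comes from compound 2 by a single change: methyl in place of hydrogen on an aromatic carbon. Among the compounds with values here, no measured pair shows what such a change does, so there is no step to lean on. Within the data shown here, with only two values known and those two within the scatter of each other, the working expectation is that the step from compound 2 to compound 3 in this assay stays within the scatter, with no particular direction: an expected step of no change at the digits printed from compound 2 to compound 3 (within the scatter).

On that basis, compound 3 is estimated at 128 ug/mL in this assay, with a range from 64 ug/mL to 256 ug/mL.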

Compound 3, half-maximal cytotoxic concentration: 64 ug/mL
For compound 3 the middle estimate is 2.0-fold (0.30 log units) above the measured one; low and high end bracket the measured number.
By their numbers in this assay, from the lowest: compounds 3, 2 and 1 (each within the scatter of the next, the first and the last beyond it).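

Within the data shown here, the first step at this position is now in hand: in this assay, methyl in place of hydrogen on an aromatic carbon of the six-membered aromatic ring of carbon only comes with a 2.0-fold lower number from compound 2 to compound 3 (0.30 log units; within the scatter), so methyl and hydrogen cannot be separated here on this single pair. The same methyl is present in compound 3, which gives 64 ug/mL, and in compound 1, which gives 256 ug/mL; these two differ at the ring-fused dione end, and their values lie beyond the scatter of each other, so that end, rather than this aromatic position, carries the only gap of that size among the compounds shown. Nothing at hand bears on what lies behind either reading.

Still open, from the compounds shown here alone, is whether a larger or different group at this aromatic carbon, such as methoxy, chlorine or an amine, would give a step beyond the scatter. Also open, going by these compounds, is whether the methyl step would read the same with hydrogen in place of methyl on the ring-fused dione end of compound 1, or with methyl on another carbon of that ring.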